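The source may report more compounds than this note shows. Statements on the series, on what has been measured and on what is new or still open speak of the compounds shown alone.

Of the compounds shown here, three have so far been measured in a functional assay on LNCaP cells (Homo sapiens) for cytotoxicity, read by MTT assay, with a stated time of 48 h, in the absence of a further agent; on this read-out higher numbers stand for weaker inhibition and lower numbers for stronger inhibition. Compound 1 `COc1ccc(NC(=O)c2csc(-c3cn(Cc4ccc(Cl)cc4)c4ccccc34)n2)cc1` reaches only the limit of this assay, > 100000 nM, with no number behind it. Compound 2 `O=C(Nc1ccccc1)c1csc(-c2cn(Cc3ccc(Cl)cc3)c3ccccc23)n1` gives 64100 nM in this assay. Within the data shown here, the single measured step, an at least 1.5-fold lower number from compound 1 to compound 2 (0.19 log units; that floor lies within the scatter), joins these two compounds. Compound 3 `COc1ccc2[nH]cc(-c3nc(C(=O)Nc4cc(OC)c(OC)c(OC)c4)cs3)c2c1` likewise stands at a limit, > 100000 nM, so only a floor for its number is known. Of the three values, two therefore sit on (the limit of > 100000 nM in this assay, at which 2 of the 3 values shown sit), and compound 2 alone yields a number.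

Compound 4 `COc1cc(NC(=O)c2csc(-c3c[nH]c4ccc(Br)cc34)n2)cc(OC)c1OC` differs from compound 3 by bromo in place of methoxy on an aromatic carbon. Among the measured compounds shown here, the one measured step, an at least 1.5-fold lower number from compound 1 to compound 2 (0.19 log units; that floor lies within the scatter), also removed a methoxy group, but on another part of the molecule, and it did not leave the scatter, so it gives only weak guidance. For the measured compounds named here, no measured step replaces a methoxy with a bromo. In this assay, the expected step is a number no higher from compound 3 to compound 4 (the limit leaves the size open), none beyond the scatter. Compound 4 is therefore expected to remain near the limit of this assay, with an estimated 100000 nM and a range from 40000 nM to 300000 nM.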

Compound 4, half-maximal inhibitory concentration: > 100000 nM
Compound 4 gave a limit, no number; the forecaster's own chance of this, stated with the estimate: 70%; the middle value sits exactly at the limit.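

Compound 3 and compound 4 both stop at a limit and give no number, so the step of bromo in place of methoxy between them cannot be read: the limit of > 100000 nM in this assay, at which 3 of the 4 values shown sit.

The compounds shown leave open whether this exchange on an aromatic carbon changes the number at all, and how far past the limit either compound lies.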